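This account rests on a few compounds, and the source may have more. Where it says the series, first, only, none or still open, it means among the compounds named here.

Measured compounds in an ADME assay (liver) for metabolic stability, with Liver microsome (Homo sapiens) as the target, using microsomes, with a stated time of 30 min, tested at 1 uM; on this read-out lower numbers stand for a less stable compound and higher numbers for a more stable compound:

compound 1 `COc1cccc(S(=O)(=O)c2ccc(CN/C(=N\C#N)Nc3ccncc3)cc2)c1`, 55%
compound 2 `N#C/N=C(\NCc1ccc(S(=O)(=O)c2cccc(C(F)(F)F)c2)cc1)Nc1ccncc1`, 62%
compound 3 `N#C/N=C(\NCc1ccc(S(=O)(=O)N2CC3CCC(C2)O3)cc1)Nc1cccnc1`, 52%

Compound 2 stands at the top of these three numbers, but the separation is small: the step of a number 7 percentage points higher from compound 1 to compound 2 (within the scatter) is within the scatter, and compound 3 with 52% sits within the scatter of compound 2 as well. On the numbers shown, then, the three measured compounds are not distinguished in this assay.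

Compound 4 `N#C/N=C(\NCc1ccc(S(=O)(=O)c2cccc3cccnc23)cc1)Nc1ccncc1` is not yet measured. It differs from compound 2 by quinolin-8-yl in place of 3-(trifluoromethyl)phenyl on a sulfonyl sulfur. Among the measured compounds shown here, the one measured step that bears on this change is the exchange of the group on the sulfonyl sulfur going from compound 1 to compound 2, a number 7 percentage points higher from compound 1 to compound 2 (within the scatter), which did not leave the scatter. For the measured compounds named here, no measured pair shows a quinolin-8-yl group in this place, so the change from compound 2 to compound 4 rests on that single precedent.

On this basis no step beyond the scatter is expected in this assay: the estimated step is a number 7 percentage points lower from compound 2 to compound 4 (within the scatter). For compound 4 the expected value in this assay is 55%, with a range from 35% to 72%.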

Compound 4, percent of the compound remaining in the Liver microsome assay: 10%
Compound 4: middle estimate off by 45 percentage points, on the high side, outside the stated range (below it).
By their numbers in the Liver microsome assay, from the lowest: compound 4; then compounds 3, 1 and 2 (each within the scatter of the next).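

In the Liver microsome assay the group on the sulfonyl sulfur matters far more than the earlier pair showed: with quinolin-8-yl compound 4 gives 10%, which is a number 52 percentage points lower from compound 2 to compound 4 (beyond the scatter) and a number 45 percentage points lower from compound 1 to compound 4 (beyond the scatter), whereas trifluoromethyl in place of methoxy gave only a number 7 percentage points higher from compound 1 to compound 2 (within the scatter). This position can therefore move the read-out beyond the scatter, and of the three groups compared here on the sulfonyl sulfur, only quinolin-8-yl does so. The same change does not leave the scatter in a physicochemical assay for solubility, with a stated time of 24 h (a lower number here means a less soluble compound, a higher number a more soluble compound), with a 1.6-fold lower number from compound 2 to compound 4 (0.19 log units; within the scatter): compound 2 gives 28000 nM and compound 4 gives 18000 nM.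

No measurement shown gives a reason for the large drop in the percentage remaining. From the compounds shown here alone, it remains open whether the drop follows the ring nitrogen of quinolin-8-yl or the second aromatic ring, a question that a naphthalen-1-yl group on the sulfonyl sulfur, with carbon-only rings, would address.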